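The source may hold more compounds than are shown below. What is called first, only, known or untested is meant among the compounds shown, and "the series" means these compounds.

Compound 1 `Nc1scc(-c2ccccc2F)c1C(=O)c1ccccc1` gives 55% in a functional assay on CHO cells for agonist activity at adenosine receptor A1 (Homo sapiens), read by fluorescence and ERK phosphorylation, with stated times of 30 min and 1.5 h, tested at 3 uM; a higher number here means a stronger effect of the compound at the concentration tested, a lower number a weaker effect. Compound 2 `Nc1scc(-c2ccc(Br)cc2)c1C(=O)c1ccccc1` gives 46%. Compound 3 `Nc1scc(-c2ccccc2F)c1C(=O)c1ccc(Cl)cc1` gives 70%.

Compound 3 stands highest of the three numbers: the nearest is compound 1, a change of a number 15 percentage points higher from compound 1 to compound 3 (beyond the scatter), and compound 2 lies furthest below it. Compound 4 `Nc1scc(-c2cccc(Br)c2)c1C(=O)c1ccc(Cl)cc1` has not yet been measured; it differs from compound 3 in one place, (3-bromophenyl in place of 2-fluorophenyl on an aromatic carbon). For the measured compounds named here, one measured step bears on this change: a number 9 percentage points lower from compound 1 to compound 2 (within the scatter), where 4-bromophenyl replaced 2-fluorophenyl. The bromine here sits at the 3-position instead, so that step is only a partial guide. On that basis the step is expected to be small or none beyond the scatter, a number 8 percentage points lower from compound 3 to compound 4 (within the scatter). Compound 4 is therefore estimated at 62%, in a range from 45% to 78%.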

Compound 4, a percentage reported as activity, at one concentration (the size of the read-out at that concentration, not a potency): 62%
The estimate for compound 4 equals the measured number at the digits printed; the range from low to high includes it.
By their numbers in this assay, from the lowest: compounds 2, 1, 4 and 3 (each within the scatter of the next, the first and the last beyond it).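

The change a number 8 percentage points lower from compound 3 to compound 4 (within the scatter) shows that in this assay, 3-bromophenyl can replace 2-fluorophenyl at this position of the shared core when the chloro group is present. Alongside a number 9 percentage points lower from compound 1 to compound 2 (within the scatter), this gives a second bromophenyl replacement within the scatter, although compounds 2 and 4 differ in two places and cannot be compared directly. Nothing available here explains the result. On these data alone, the effect of moving the bromine with the chloro group held constant remains open. So does the outcome of placing a pyridine ring or a carboxylic acid-bearing phenyl at this position.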